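The source may hold more compounds than are shown below. What is called first, only, known or untested is meant among the compounds shown, and "the series" means these compounds.

Measured compounds:
Compound 1 `O=c1cc(NC2CCCCC2)cc(/C=C/c2ccccc2)o1` — 2.02 uM
Compound 2 `O=c1cc(Nc2ccccc2)cc(-c2ccccc2)o1` — 0.13 uM

In a functional assay on KB cells (Homo sapiens) for cytotoxicity, read by MTT assay, with a stated time of 72 h (on this read-out lower numbers stand for an effect already at smaller amounts and higher numbers for an effect only at larger amounts of compound), compound 1 gives the highest of the two numbers; compound 2, which differs from it in two places, gives the lower one. Compound 3 `COc1ccc(Nc2cc(/C=C/c3ccccc3)oc(=O)c2)cc1` keeps the core of compound 1 with one change: 4-methoxyphenyl in place of cyclohexyl on a nitrogen on an aromatic ring. Going by the values given here, no measured pair isolates this change, so the aryl-for-cyclohexyl swap cannot be read off compound 2 alone. An estimated step from a 2.5-fold lower number from compound 1 to compound 3 (0.40 log units; beyond the scatter), a modest move toward a lower number that may still sit close to the scatter, seems plausible. Compound 3 is therefore expected to give about 0.8 uM, within 0.2 uM to 3 uM.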

Compound 3, concentration for half-maximal effect: 0.15 uM
Beside the measured number, compound 3's estimate is 5.3-fold (0.73 log units) above it; the measured number lies below the stated range.
By their numbers in this assay, from the lowest: compounds 2 and 3 (each within the scatter of the next); then compound 1.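

In this assay, 4-methoxyphenyl in place of cyclohexyl on a nitrogen on an aromatic ring gives a 13-fold lower number from compound 1 to compound 3 (1.13 log units; beyond the scatter), a large step from this one change. This shows that the group on this nitrogen can by itself move the number well beyond the scatter, which compound 2, differing from compound 1 in two places, could not show. Nothing measured here accounts for the step. Going by these compounds, it remains open whether the aromatic ring or its methoxy group carries the step, a question that plain phenyl on this nitrogen in the core of compound 1 would address. On these data alone, how a carboxylic acid or an amine on that ring would fare also remains open.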